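A few compounds are considered here, and "the series" means these few. Any claim that something is new, unique, unknown or untested is made for them only; others in the source may bear on it.

Compound 1 `O[C@H](COCCOC[C@@H](O)Cc1cn(-c2cccs2)nn1)Cc1ccc(-c2ccccc2)cc1` gives 33400 nM in a functional assay on SGC-7901 cells (Homo sapiens) for inhibition, read by MTT assay, with a stated time of 72 h; a higher number here means a weaker inhibitor of growth, a lower number a stronger inhibitor of growth. Compound 2 `O[C@H](COCCOC[C@@H](O)Cc1c[nH]nn1)Cc1ccc(-c2ccccc2)cc1` reaches only a limit of this assay, > 100000 nM. Compound 3 `O[C@H](COCCOC[C@@H](O)Cc1cn(-c2cncc3ccccc23)nn1)Cc1ccc(-c2ccccc2)cc1` gives 29300 nM in this assay.

Compound 3 thus holds one of the two real numbers; the other belongs to compound 1, and a 1.1-fold lower number from compound 1 to compound 3 (0.06 log units; within the scatter), so the two cannot be ranked. The third value is a limit, (the limit of > 100000 nM in this assay, at which 1 of the 3 values shown sits).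

Compound 4 `N#Cc1ccc(Cn2cc(C[C@H](O)COCCOC[C@@H](O)Cc3ccc(-c4ccccc4)cc3)nn2)cc1` is not yet measured. Its change from compound 3 is 4-cyanobenzyl in place of isoquinolin-4-yl on an aromatic nitrogen. Among the measured compounds shown here, three measured steps touch this position. Removing the aromatic group altogether gave an at least 2.9-fold higher number from compound 1 to compound 2 (0.47 log units; beyond the scatter), and restoring one gave an at least 3.4-fold lower number from compound 2 to compound 3 (0.53 log units; beyond the scatter); swapping one aromatic group for another gave a 1.1-fold lower number from compound 1 to compound 3 (0.06 log units; within the scatter). Since compound 4 keeps an aromatic group on that nitrogen, a step within the scatter is expected, in either direction. Compound 4 is therefore estimated at 35000 nM, between 12000 nM and 100000 nM, which is expected to mean a 1.2-fold higher number from compound 3 to compound 4 (0.08 log units; within the scatter).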

Compound 4, concentration for 50% growth inhibition: 7700 nM
The estimate for compound 4 lay 4.5-fold (0.66 log units) above the measured number; measured number outside the range, below it.
By their numbers in this assay, from the lowest: compound 4; then compounds 3 and 1 (each within the scatter of the next). At a limit, above all of these: compound 2.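

The nitrogen substituent does more than need to be present: its identity can matter. Thiophen-2-yl and isoquinolin-4-yl could not be told apart, yet 4-cyanobenzyl separates from both, with a 3.8-fold lower number from compound 3 to compound 4 (0.58 log units; beyond the scatter) and a 4.3-fold lower number from compound 1 to compound 4 (0.64 log units; beyond the scatter), making compound 4 the strongest growth inhibitor of the four. Against the unsubstituted triazole nitrogen the gain is wider, with an at least 12-fold lower number from compound 2 to compound 4 (1.11 log units; beyond the scatter), although the value of compound 2 is a limit of the assay rather than a number.

Nothing measured here explains the gain. From the compounds shown here alone, it remains open whether the nitrile or the benzyl part carries the change, which a plain benzyl group, a 4-aminobenzyl group or a 4-carboxybenzyl group at this nitrogen would help to separate.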